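A few compounds are considered here, and "the series" means these few. Any claim that something is new, unique, unknown or untested is made for them only; others in the source may bear on it.

Compound 1 `COc1ccc2nc(C)cc(NCC(=O)Nc3cc(C)cc(C)c3)c2c1` and compound 2 `COc1ccc2nc(C)cc(OCC(=O)Nc3ccc(Cl)cc3Cl)c2c1` share one core and differ in the linking group and in the aryl amide. In a physicochemical assay for solubility, in phosphate buffer, measured as kinetic solubility, with a stated time of 1 h, at pH 7.4 (a higher number here means a more soluble compound, a lower number a less soluble compound), compound 1 gives 204000 nM, while compound 2 gives 20500 nM, the lower of the two numbers, with the gap to compound 1 beyond the scatter. Compound 3 `COc1ccc2nc(C)cc(OCC(=O)Nc3nc(C)c(C)s3)c2c1` carries a single change against compound 2: 4,5-dimethyl-1,3-thiazol-2-yl in place of 2,4-dichlorophenyl on an amide-type nitrogen. Within the data shown here, no step between measured compounds is known here, so the outcome rests on this change alone. In this assay a moderate rise is expected, a 2.9-fold higher number from compound 2 to compound 3 (0.47 log units; beyond the scatter), beyond the scatter. Compound 3 is therefore estimated at 60000 nM, in a range from 20000 nM to 180000 nM.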

Compound 3, solubility: 31500 nM
Compound 3: the middle estimate sits 1.9-fold (0.28 log units) above what was measured, within the range that was stated.
By their numbers in this assay, from the lowest: compounds 2 and 3 (each within the scatter of the next); then compound 1.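

In this assay, 4,5-dimethyl-1,3-thiazol-2-yl in place of 2,4-dichlorophenyl on the amide-type nitrogen gives a 1.5-fold higher number from compound 2 to compound 3 (0.19 log units; within the scatter) and so does not separate the two compounds. At this position, a five-membered aromatic ring with 2 hetero atoms and a six-membered aromatic ring of carbon only thus give solubility values within the scatter of each other. No measurement shown here offers an explanation for this result. From the compounds shown here alone, whether an amine or a carboxylic acid on this nitrogen's aryl group would shift solubility remains open. Going by these compounds, the separate contributions of the linking group and the aryl amide also remain open, since compound 1 and compound 2 differ in both places.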